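Lengthening the hydroxyalkyl chain on the triazole

A few compounds are considered here, and "the series" means these few. Any claim that something is new, unique, unknown or untested is made for them only; others in the source may bear on it.

Compound 1, `O=c1cc(Cn2cc(C3CC3)nn2)c2ccc(O)cc2o1`, in a functional assay on HeLa cells (Homo sapiens) for inhibition, read by MTT assay, with a stated time of 72 h (a higher number here means a weaker inhibitor, a lower number a stronger inhibitor), gives > 100000 nM, which is a limit of the assay rather than a number.
Compound 2, `CC(O)c1cn(Cc2cc(=O)oc3cc(O)ccc23)nn1`, in this assay gives > 100000 nM, again a limit of the assay.
Compound 3, `O=c1cc(Cn2cc(CCCO)nn2)c2ccc(O)cc2o1`, in this assay gives 90200 nM.

Within the data shown here, compound 3 therefore stands as the only compound of the three with an actual number; the other two are described by the limit of > 100000 nM in this assay, at which 2 of the 3 values shown sit. Compound 4, `O=c1cc(Cn2cc(CCCCO)nn2)c2ccc(O)cc2o1`, has not yet been tested. It differs from compound 3 by hydroxymethyl in place of hydroxy on a saturated chain carbon, three bonds along the chain from an aromatic carbon, so the chain carrying the hydroxy group grows by one carbon.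

The measured steps that bear on this are the chain changes leading into compound 3: an at least 1.1-fold lower number from compound 1 to compound 3 (0.04 log units; that floor lies within the scatter) and an at least 1.1-fold lower number from compound 2 to compound 3 (0.04 log units; that floor lies within the scatter). Both steps reach only a floor, and that floor lies within the scatter, so they say little about how chain length matters here. With compound 3 already close to the limit, no clear movement is expected for compound 4: the step of a 1.1-fold higher number from compound 3 to compound 4 (0.02 log units; within the scatter) is estimated to stay within the scatter. Compound 4 is therefore expected to give about 95000 nM, within a range from 30000 nM to 300000 nM, with a fair chance that the assay reports only a limit.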

Compound 4, half-maximal inhibitory concentration: > 100000 nM
Compound 4: only a limit was reported; the forecaster's own chance of this, stated with the estimate: 50%; middle value at least 1.0-fold (0.02 log units) from the limit.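

Adding one carbon to turn 3-hydroxypropyl into 4-hydroxybutyl gives an at least 1.1-fold higher number from compound 3 to compound 4 (0.04 log units; that floor lies within the scatter), so lengthening the chain at this position shows no readable change in this assay. The steps from compound 1 and from compound 2 to compound 4 cannot be read, as each joins two limits of the assay. The longer chain therefore opens no visible route to lower numbers, and compound 3 remains the only compound with an actual value, leaving the series at the edge of what the assay can report: the limit of > 100000 nM in this assay, at which 3 of the 4 values shown sit.

As far as these compounds go, whether any group on this aromatic carbon can give a clearly lower number stays open, for instance an amine or a carboxylic acid at the end of the chain in place of the hydroxy, or a phenyl ring in place of the chain. Also open, from the compounds shown here alone, is whether changes to the shared core, rather than to this chain, would move the number at all, and with values this close to the limit the four compounds cannot rank their groups against one another.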